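Moving the amide link around the indole ring

The source may hold more compounds than are shown below. What is called first, only, known or untested is meant among the compounds shown, and "the series" means these compounds.

Three compounds share one core: a methoxyphenyl piperazine joined through a three-carbon chain to an amide whose carbonyl carries an indole. In an assay on isolated protein (thoracic aorta, strain Sprague-Dawley) for antagonist activity at Alpha-1D adrenergic receptor (Rattus norvegicus), with a stated time of 20 min (on this read-out lower numbers stand for tighter binding and higher numbers for weaker binding), compound 1 `COc1ccccc1N1CCN(CCCNC(=O)c2ccc3[nH]ccc3c2)CC1` gives 11.8 nM, compound 2 `COc1ccccc1N1CCN(CCCNC(=O)c2cc3cc(O)ccc3[nH]2)CC1` gives 26.9 nM, and compound 3 `COc1ccccc1N1CCN(CCCNC(=O)c2cc3cc(Cl)ccc3[nH]2)CC1` gives 19.5 nM. Compound 3 sits between the other two, and its numbers differ from those of compound 2 and of compound 1 by amounts that repeated measurement could produce on its own.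

Compound 4 `COc1ccccc1N1CCN(CCCNC(=O)c2cn(C)c3ccccc23)CC1` is the next step: 1-methyl-1H-indol-3-yl in place of 5-chloro-1H-indol-2-yl on a carbonyl carbon. This change removes the chlorine and the hydrogen-bond donor on the ring nitrogen, and shifts where the amide meets the indole. Among the measured compounds shown here, the measured steps bear on it only loosely: a 1.7-fold higher number from compound 1 to compound 3 (0.22 log units; within the scatter) and a 1.4-fold lower number from compound 2 to compound 3 (0.14 log units; within the scatter) show that moving the attachment point and swapping the ring substituent left this assay almost unchanged, while a 2.3-fold higher number from compound 1 to compound 2 (0.36 log units; beyond the scatter) was the only change that reached beyond the scatter. For the measured compounds named here, no measured pair tests loss of the ring nitrogen hydrogen. Against this background the expected outcome is a 1.2-fold lower number from compound 3 to compound 4 (0.09 log units; within the scatter), with no clear direction, so compound 4 is estimated at 16 nM, within a range from 5 nM to 50 nM.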

Compound 4, dissociation constant: 5.5 nM
Beside the measured number, compound 4's estimate is 2.9-fold (0.46 log units) above it; the measured number falls inside the stated range.
By their numbers in this assay, from the lowest: compound 4; then compounds 1, 3 and 2 (each within the scatter of the next, the first and the last beyond it).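

In this assay, among the compounds shown here, putting 1-methyl-1H-indol-3-yl on the carbonyl carbon in place of 5-chloro-1H-indol-2-yl gives a 3.5-fold lower number from compound 3 to compound 4 (0.55 log units; beyond the scatter) and is the first change to lower the number beyond the scatter. The other two comparisons point the same way, with a 4.9-fold lower number from compound 2 to compound 4 (0.69 log units; beyond the scatter) and a 2.1-fold lower number from compound 1 to compound 4 (0.33 log units; beyond the scatter) leaving compound 4 with the lowest number of the four, so the group on this carbonyl carbon can tighten binding and not merely weaken it or leave it almost unchanged. Nothing available here gives a measured reason for this shift.

Each of these steps changes more than one feature at once, as the attachment point on the indole, the methyl on the ring nitrogen and the ring substituent differ together, so the compounds shown cannot say which of these features accounts for the lower number. A plain 1H-indol-3-yl group would separate the methyl from the attachment point, while a 1-ethyl-1H-indol-3-yl group would show whether a longer chain on the ring nitrogen lowers the number further or raises it.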